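Swapping the Aryl Ring on the Amine Nitrogen

A few compounds are considered here, and "the series" means these few. Any claim that something is new, unique, unknown or untested is made for them only; others in the source may bear on it.

Compound 3 `CC1CC/C(=N\Nc2ccccc2F)c2ncc(C(=O)O)c(=O)n21` was tested in a functional assay on the whole organism for inhibition, with Rattus norvegicus as the target; a lower number here means that less compound is needed, a higher number that more compound is needed for the effect. Compound 3 reached only the limit of the measurement, > 1000 umol/kg, so no number is known for it. Compound 1 `CC1CC/C(=N\Nc2ccccc2)c2ncc(C#N)c(=O)n21` likewise gave only a limit, > 1000 umol/kg. Compound 2 `CC1CCC(=NNc2ccccc2)c2ncc(C(=O)O)c(=O)n21`, by contrast, gave 1.2 umol/kg in this assay. Two of the three values thus sit at the same place, (the limit of > 1000 umol/kg in this assay, at which 2 of the 3 values shown sit). Compound 4 `COc1ccc(N/N=C2\CCC(C)n3c2ncc(C(=O)O)c3=O)cc1` differs from compound 3 in one place: 4-methoxyphenyl in place of 2-fluorophenyl on an amine nitrogen. Among the measured compounds shown here, whether this change brings measurable inhibition is open, as no step between measured compounds has been followed. Compound 4 is expected to come in under the limit, at roughly 30 umol/kg, with a range from 1 umol/kg to 1000 umol/kg. The expected step of an at least 33-fold lower number from compound 3 to compound 4 (1.52 log units; beyond the scatter) is therefore a gain in this assay, though a limit result remains possible.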

Compound 4, dose for 50% inhibition: 7.6 umol/kg
For compound 4 the middle estimate is 3.9-fold (0.60 log units) above the measured one; the range from low to high includes it.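

Among the compounds shown here, exchanging 2-fluorophenyl for 4-methoxyphenyl on the amine nitrogen gives an at least 130-fold lower number from compound 3 to compound 4 (2.11 log units; beyond the scatter) in this assay, the first step that can be followed at this position. A change in this aryl group alone therefore separates a measurable result from a limit result. The value of compound 3 is a limit and not a number, so the step gives only a minimum size: the limit of > 1000 umol/kg in this assay, at which 2 of the 4 values shown sit.

The step changes both the substituent and its place on the ring, and the compounds shown do not separate the two. Going by these compounds, whether 4-fluorophenyl or 2-methoxyphenyl would give a measurable value remains open.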